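The compounds below may be only part of what the source reports. "The series", "measured", "known", "first", "only" and "open" are said of these compounds alone.

Measured in a functional assay for inhibition, with Homo sapiens as the target; a lower number here means a stronger inhibitor, a higher number a weaker inhibitor:
- compound 1 `Oc1cc2c(cc1CNc1ccccc1)OCCC2`: 1700 nM
- compound 2 `Oc1cc2c(cc1CNc1ccc(F)cc1F)OCCC2`: 1300 nM
- compound 3 `OCc1ccccc1NCc1cc2c(cc1O)CCCO2`: 21000 nM

Compound 1 at 1700 nM lies within the scatter of compound 2 at 1300 nM, so these two values give no order. Compound 3 stands well apart from them, at a much higher number.

Compound 4 `CCOC(=O)c1ccc(NCc2cc3c(cc2O)CCCO3)cc1` is the next case: ethoxycarbonyl in place of hydrogen on an aromatic carbon. The change is ethoxycarbonyl in place of hydrogen on an aromatic carbon, para to a large group.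

Going by the values given here, only one measured single change bears on this: a 12-fold higher number from compound 1 to compound 3 (1.09 log units; beyond the scatter), with hydroxymethyl in place of hydrogen on an aromatic carbon. That step is large, and it shows that a single addition can cost much in this assay. However, it involves a different group, and one step cannot set a size for another. A moderate move toward a higher number is therefore expected, smaller than the step seen with compound 3, with wide uncertainty. The expected step is a 2.1-fold higher number from compound 1 to compound 4 (0.31 log units; beyond the scatter). For compound 4 the estimate is 3500 nM, with an expected range from 900 nM to 13000 nM.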

Compound 4, half-maximal inhibitory concentration in the Homo sapiens assay: 600 nM
Compound 4: the middle estimate sits 5.8-fold (0.77 log units) above what was measured; the whole stated range lies above it.
By their numbers in the Homo sapiens assay, from the lowest: compound 4; then compounds 2 and 1 (each within the scatter of the next); then compound 3.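

In the Homo sapiens assay, ethoxycarbonyl in place of hydrogen on an aromatic carbon, para to a large group, gives a 2.8-fold lower number from compound 1 to compound 4 (0.45 log units; beyond the scatter), so this position accepts an added group of 5 heavy atoms with a gain in inhibition rather than a loss. The only earlier single addition, hydroxymethyl, went the other way, with a 12-fold higher number from compound 1 to compound 3 (1.09 log units; beyond the scatter), so an added group on this ring does not have to cost inhibition. In a physicochemical assay for lipophilicity (a lower number here means a more polar compound, a higher number a more lipophilic compound), compound 1 stands at 3.5 and compound 4 at 4.6 on this scale. In the physicochemical assay, the same change also makes the compound more lipophilic: the measured partition coefficient of compound 1, 3.5, and of compound 4, 4.6, a number 1.10 log units higher (beyond the scatter)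

Going by these compounds, whether the gain follows the ester group itself or the rise in lipophilicity stays open, and compound 4 alone does not separate the two. A carboxylic acid or a primary amide at the same place, with a longer chain on the ester as a further case, would bear on that question.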